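The compounds below may be only part of what the source reports. "The series", "measured", "known", "first", "only" and "open" are said of these compounds alone.

Compound 1 `CCCCC1(O)C(=O)Nc2ccc(Nc3ccc(C(F)(F)F)cc3)cc21`: 12000 nM
Compound 2 `CC(C)CCC1(O)C(=O)Nc2ccc(Nc3ccc(C(F)(F)F)cc3)cc21`: 17200 nM

Both compounds were tested in a functional assay on NCI-H460 cells (Homo sapiens) for antiproliferative activity, read by MTT assay, with a stated time of 48 h; a higher number here means a weaker inhibitor, a lower number a stronger inhibitor. They share a core and differ only in one chain. For the measured compounds named here, compound 2 has only this one neighbour on the scale, and the two values cannot be told apart: the measured difference is a 1.4-fold higher number from compound 1 to compound 2 (0.16 log units; within the scatter).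

Compound 3 `CCCCCCC1(O)C(=O)Nc2ccc(Nc3ccc(C(F)(F)F)cc3)cc21` keeps the core and changes that chain again: butyl in place of isopropyl on a saturated chain carbon, two bonds along the chain from a saturated ring carbon. This places butyl in place of isopropyl on a saturated chain carbon, two bonds along the chain from a saturated ring carbon, so the whole chain goes from isopentyl to hexyl.

Going by the values given here, only one measured step bears on this change, and it is small: adding a methyl in place of hydrogen on this chain gave a 1.4-fold higher number from compound 1 to compound 2 (0.16 log units; within the scatter). One step is thin evidence, but it gives no reason to expect a large shift. The expected step is a 1.4-fold lower number from compound 2 to compound 3 (0.16 log units; within the scatter), which means no expected change beyond the scatter. Compound 3 is estimated at 12000 nM, with an expected range from 5000 nM to 28000 nM.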

Compound 3, half-maximal inhibitory concentration: 18800 nM
Compound 3: middle estimate off by 1.6-fold (0.19 log units), on the low side; measured number inside the range.
By their numbers in this assay, from the lowest: compounds 1, 2 and 3 (each within the scatter of the next).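

Replacing the branched isopentyl chain with the straight hexyl chain gives no readable difference in this assay (a 1.1-fold higher number from compound 2 to compound 3 (0.04 log units; within the scatter)). Extending the butyl chain of compound 1 to the hexyl chain of compound 3 also stays within the scatter (a 1.6-fold higher number from compound 1 to compound 3 (0.19 log units; within the scatter)). Compound 1, compound 2 and compound 3 therefore cannot be told apart, so neither the branch nor the added length separates these three chains, and nothing available explains why their numbers lie so close together.

These three compounds cover only saturated, all-carbon chains at this position. As far as these compounds go, whether a much longer chain, or a chain ending in an amine, a carboxylic acid or a phenyl ring, would give a number clearly different from these remains open.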